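Working notes: from compound 2 toward compound 3

The source may report more compounds than this note shows. Statements on the series, on what has been measured and on what is new or still open speak of the compounds shown alone.

Measured compounds:
compound 1 `O=C(Nc1ccc(S(=O)(=O)NCc2ccccc2)cc1)c1ccc(Cl)cc1Cl` — "not determined" (no result reported) in a functional assay on HEK293 cells for agonist activity at probable G-protein coupled receptor 27 (Homo sapiens), read by a luciferase reporter and beta-arrestin recruitment, with a stated time of 10 min; a lower number here means a smaller maximal response, a higher number a larger maximal response
compound 2 `O=C(Nc1ccc(S(=O)(=O)Nc2ccccc2)cc1)c1ccc(Cl)cc1Br` — 123%

For the measured compounds named here, compound 2 holds the only number so far: in this assay compound 2 gives 123%, a maximal response above the reference. Going by the values given here, compound 1 has no result, so no step between two measured compounds exists and there is no yardstick for how much a single change moves the maximal response.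

Compound 3 `O=C(Nc1ccc(S(=O)(=O)Nc2ccccc2)cc1)c1ccc(Br)cc1F` differs from compound 2 in one place: 4-bromo-2-fluorophenyl in place of 2-bromo-4-chlorophenyl on a carbonyl carbon. Both the leaving and the entering group are a six-membered carbon ring bearing two halogens, with no donor or acceptor added or removed, so the exchange is a redistribution of halogens on the ring attached to the carbonyl carbon. Among the compounds with values here, with no measured step to lean on, the expectation is a step in this assay of small to moderate size, most likely downward, and possibly none beyond the scatter. Compound 3 is expected to give 105%, with a range from 65% to 140%. The estimated step of a number 18 percentage points lower from compound 2 to compound 3 (beyond the scatter) is modest and leaves compound 3 near a full response.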

Compound 3, largest response reached (Emax), in percent of the reference or control that the assay uses: 67%
Beside the measured number, compound 3's estimate is 38 percentage points above it, and the stated range covers the measured number.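

In this assay, for the compounds shown here, the exchange of 2-bromo-4-chlorophenyl for 4-bromo-2-fluorophenyl on a carbonyl carbon gives a number 56 percentage points lower from compound 2 to compound 3 (beyond the scatter) and provides the first readable step. The group on the carbonyl carbon is therefore a place where a change of halogens alone can shift the maximal response well beyond the scatter, with compound 3 reaching 67% in this assay and no change in the counts of heavy atoms, hydrogen-bond donors or hydrogen-bond acceptors, or in net charge. No measurement here bears on the reason for this drop.

The two groups differ in both the kind and the arrangement of their halogens, so this single step cannot assign the loss to the fluorine, the absent chlorine or the relocated bromine. Going by these compounds, it also remains open whether the maximal response would hold with a 4-bromo-2-chlorophenyl group on the carbonyl carbon, or with a non-halogen substituent such as methoxy or nitrile on that ring.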